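The source may report more compounds than this note shows. Statements on the series, on what has been measured and on what is new or still open speak of the compounds shown alone.

Compound 3 `CC(C)Cc1nn(-c2nccs2)cc1C(=O)NCc1ccc(O)cc1` is one of three compounds with readings in a toxicity assay on HepG2 2.2.15 cells (Homo sapiens) for cytotoxicity, read by CCK-8 assay, with a stated time of 8 days; on this read-out lower numbers stand for higher toxicity in this test and higher numbers for lower toxicity in this test. Compound 1 `CC(C)Cc1nn(-c2nccs2)cc1C(=O)NCc1ccc(F)cc1F` gives 83600 nM in this assay, and compound 2 `COc1ccc(CONC(=O)c2cn(-c3cccc(F)c3)nc2CC(C)C)cc1` gives 67900 nM. For compound 3 this assay reports only a limit, > 100000 nM. That is the limit at which (the limit of > 100000 nM in this assay, at which 1 of the 3 values shown sits), so compound 3 stands at the top edge of what the numbers can show, without a measured value of its own. Going by the values given here, the single one-place step among the measured compounds, an at least 1.1-fold higher number from compound 1 to compound 3 (0.07 log units; that floor lies within the scatter), is itself only a floor, and that floor lies within the scatter.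

Compound 4 `CC(C)Cc1nn(-c2nccs2)cc1C(=O)NCc1ccc(F)cc1` differs from compound 3 by fluoro in place of hydroxy on an aromatic carbon. Among the compounds with values here, the one measured step that touches this place, an at least 1.1-fold higher number from compound 1 to compound 3 (0.07 log units; that floor lies within the scatter), ran from a fluorinated ring to the hydroxy ring without a change beyond the scatter, and the change now runs back toward a fluorinated ring by a single atom. Within the data shown here, nothing among the measured compounds points to a step beyond the scatter in either direction. The step expected here, an at least 1.1-fold lower number from compound 3 to compound 4 (0.04 log units; that floor lies within the scatter), stays within the scatter. Compound 4 is therefore estimated at 90000 nM, with a range from 45000 nM to 180000 nM, and it may well come back as a limit once more.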

Compound 4, half-maximal cytotoxic concentration: > 100000 nM
Compound 4 gave a limit, no number; the forecaster's own chance of this, stated with the estimate: 40%; at least 1.1-fold (0.04 log units) between middle value and limit.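

With fluoro in place of hydroxy on the aromatic carbon para to a large group, the reading in this assay remains a limit, and the step between these two compounds cannot be read because neither has a measured number. Going by these compounds alone, the one readable new comparison, hydrogen in place of fluoro on an aromatic carbon, gives an at least 1.1-fold higher number from compound 1 to compound 4 (0.07 log units; that floor lies within the scatter), so it is again only a floor and shows no change beyond the scatter. What is new is that compound 3 no longer stands alone at the top edge of the read-out, and that the hydroxy, with its hydrogen-bond donor, is not needed for a reading there: the limit of > 100000 nM in this assay, at which 2 of the 4 values shown sit.

From the compounds shown here alone, how far past the limit compound 3 and compound 4 lie, and whether they differ from each other at all, stays open. Also open, going by these compounds, is whether an amine or a carboxylic acid on the same aromatic carbon would give a measured number, and how compound 2, which differs from the others in more than one place, relates to this series.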